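Pyridin-3-yl to cyclohexyl on the shared core

This account rests on a few compounds, and the source may have more. Where it says the series, first, only, none or still open, it means among the compounds named here.

Two compounds open the series: compound 1 `Nc1nc(-c2ccccn2)nn1-c1ncnc2cc(N3CCNCC3)c([N+](=O)[O-])cc12` and compound 2 `COc1cc2ncnc(-n3nc(-c4cccnc4)nc3N)c2cc1OC`. In an ADME assay on BJ cells (Homo sapiens) for cytotoxicity, with a stated time of 72 h (on this read-out higher numbers stand for an effect only at larger amounts of compound and lower numbers for an effect already at smaller amounts), compound 1 has the entry "not determined" (no result reported). In this assay compound 2 gives > 71000 nM, which is a limit of the assay and not a number. Among the compounds with values here, compound 2 therefore has no exact place on the scale, and the series offers no measured step to size a change against. Compound 3 `COc1cc2ncnc(-n3nc(C4CCCCC4)nc3N)c2cc1OC` carries cyclohexyl in place of pyridin-3-yl on an aromatic carbon. In this assay a modest move towards lower numbers is expected at most, possibly none beyond the scatter, and another limit is the likeliest report. That expectation rests on compound 2 alone, whose > 71000 nM is a limit. The estimated change is an at least 1.1-fold lower number from compound 2 to compound 3 (0.07 log units; that floor lies within the scatter). For compound 3 the expected value is 60000 nM, with an estimated range of 20000 nM to 110000 nM.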

Compound 3, half-maximal effective concentration in the BJ assay: > 27000 nM
Compound 3 was reported as a limit; the forecaster's own chance of this, stated with the estimate: 60%; the middle value lies beyond the limit too.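

In the BJ assay compound 2 gives > 71000 nM, which is a limit of the assay and not a number. In the BJ assay compound 3 gives > 27000 nM, which is also a limit of the assay and not a number. The step between them cannot be read. The compounds shown leave open where either compound lies on this scale, and whether cyclohexyl in place of pyridin-3-yl shifts it at all. In a physicochemical assay for solubility, in phosphate buffer, with a stated time of 18 h, at pH 7.4 (on this read-out lower numbers stand for lower solubility and higher numbers for higher solubility), compound 2 gives 27000 nM and compound 3 gives 35000 nM, two values within the scatter of each other.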